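The compounds below may be only part of what the source reports. "The series", "measured", "known", "first", "only" and "open" are said of these compounds alone.

In a functional assay on DU-145 cells (Homo sapiens) for cytotoxicity, read by trypan blue exclusion, with a stated time of 96 h (a lower number here means a stronger inhibitor, a higher number a weaker inhibitor), compound 1 `COc1ccc(NS(=O)(=O)/C=C/c2c(OC)cc(OC)cc2OC)cc1` gives 200 nM, compound 2 `COC(=O)CNc1cc(NS(=O)(=O)/C=C/c2c(OC)cc(OC)cc2OC)ccc1OC` gives 350 nM, and compound 3 `COC(=O)C(Nc1cc(NS(=O)(=O)/C=C/c2c(OC)cc(OC)cc2OC)ccc1OC)c1ccccc1` gives 2500 nM, the highest number of the three. Compound 4 `COc1cc(OC)c(/C=C/S(=O)(=O)Nc2ccc(OC)c(NC(C)(C)C(=O)O)c2)c(OC)c1` is still unmeasured. Its change from compound 3 is 1-carboxy-1-methylethyl in place of methoxycarbonyl)(benzyl on a nitrogen on an aromatic ring. Going by the values given here, three measured steps bear on this. Adding phenyl gave a 7.1-fold higher number from compound 2 to compound 3 (0.85 log units; beyond the scatter), and the whole group gave a 13-fold higher number from compound 1 to compound 3 (1.10 log units; beyond the scatter), whereas the group without phenyl gave only a 1.8-fold higher number from compound 1 to compound 2 (0.24 log units; within the scatter). Among the compounds with values here, the entering group has no ring, which points to a lower number, although no measured compound carries 1-carboxy-1-methylethyl. The expected move is modest: a 3.1-fold lower number from compound 3 to compound 4 (0.49 log units; beyond the scatter). For compound 4 the estimated value is 800 nM, with an expected range of 200 nM to 4000 nM.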

Compound 4, half-maximal inhibitory concentration: 70 nM
For compound 4 the middle estimate is 11-fold (1.06 log units) above the measured one; measured number outside the range, below it.
By their numbers in this assay, from the lowest: compound 4; then compounds 1 and 2 (each within the scatter of the next); then compound 3.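

In this assay, compound 4 is the first of these compounds in which a group added at this aromatic carbon lowers the number (a 2.9-fold lower number from compound 1 to compound 4 (0.46 log units; beyond the scatter)). On the nitrogen, 1-carboxy-1-methylethyl also beats both earlier groups, the one without a ring (a 5.0-fold lower number from compound 2 to compound 4 (0.70 log units; beyond the scatter)) and the one with a ring (a 36-fold lower number from compound 3 to compound 4 (1.55 log units; beyond the scatter)). Nothing measured here explains these steps.

From the compounds shown here alone, compound 4 brings in the carboxylic acid and the extra methyl groups together, so their separate shares remain unknown. Carboxymethyl, with no added methyl, would separate them, and whether an amide could replace the carboxylic acid stays open.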